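Stretching the Nitroimidazole Chain of a Bromo Compound

The compounds below may be only part of what the source reports. "The series", "measured", "known", "first", "only" and "open" are said of these compounds alone.

In a functional assay on A549 cells (Homo sapiens) for inhibition, read by sulforhodamine B assay, with a stated time of 72 h (on this read-out lower numbers stand for stronger inhibition and higher numbers for weaker inhibition), compound 2 (`C#Cc1cccc(Nc2ncnc3cc(OCCCCn4ccnc4[N+](=O)[O-])c(OC)cc23)c1`) gives 1080 nM and compound 3 (`COc1cc2c(Nc3cccc(Br)c3)ncnc2cc1OCCCCn1ccnc1[N+](=O)[O-]`) gives 1970 nM. Compound 1 (`COc1cc2c(Nc3ccc(F)c(Cl)c3)ncnc2cc1OCCCCCCn1ccnc1[N+](=O)[O-]`) gives 6520 nM, so compound 3 stands clearly apart from compound 1 but not from compound 2.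

Compound 4 (`COc1cc2c(Nc3cccc(Br)c3)ncnc2cc1OCCCCCCn1ccnc1[N+](=O)[O-]`) differs from compound 3 in a single place: 2-(2-nitro-1H-imidazol-1-yl)ethyl in place of 2-nitro-1H-imidazol-1-yl on a saturated chain carbon, four bonds along the chain from an oxygen on an aromatic ring. The change lies on a saturated chain carbon, four bonds along the chain from an oxygen on an aromatic ring.

Going by the values given here, the one measured step, a 1.8-fold higher number from compound 2 to compound 3 (0.26 log units; within the scatter), is bromo in place of ethynyl on an aromatic carbon and leaves the chain untouched, so it says little here. Compound 1 carries the chain that compound 4 gains, but on a different aromatic substitution, so compound 1 with 6520 nM is only indirect evidence that points towards a higher number.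

A modest rise near the edge of the scatter is therefore expected, estimated as a 1.8-fold higher number from compound 3 to compound 4 (0.26 log units; within the scatter) in this assay. For compound 4 the estimated value is 3600 nM, with an expected range from 1600 nM to 8000 nM.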

Compound 4, half-maximal inhibitory concentration: 20200 nM
Estimate against measurement, compound 4: 5.6-fold (0.75 log units) below; measured number outside the range, above it.
By their numbers in this assay, from the lowest: compounds 2 and 3 (each within the scatter of the next); then compound 1; then compound 4.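

In this assay, going by these compounds alone, lengthening the chain carries a large penalty: 2-(2-nitro-1H-imidazol-1-yl)ethyl in place of 2-nitro-1H-imidazol-1-yl gives a 10-fold higher number from compound 3 to compound 4 (1.01 log units; beyond the scatter) on the saturated chain carbon, the first direct reading of this position, as the only earlier step left the chain untouched. With the longer chain held fixed, the aromatic group also matters: 3-bromophenyl in place of 3-chloro-4-fluorophenyl on the nitrogen gives a 3.1-fold higher number from compound 1 to compound 4 (0.49 log units; beyond the scatter) in the same direction. Nothing shown gives a reason for either step.

The compounds shown leave open whether the same lengthening would cost as much on the ethynyl compound 2, and how a still longer chain would read. On these data alone, it also remains open whether an amine at the chain end could stand in for 2-nitro-1H-imidazol-1-yl.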